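The compounds below may be only part of what the source reports. "The series", "measured", "known", "first", "only" and "open" are said of these compounds alone.

Measured so far in a functional assay on cells (Homo sapiens) for cytotoxicity, read by MTT assay, with a stated time of 24 h; a higher number here means a weaker inhibitor, a lower number a stronger inhibitor:
- compound 1 `CCCCCCCCCCCCCCNC(=O)[C@H](CO)/N=C/c1cccc(C)c1`: 82900 nM
- compound 2 `CCCCCCCCCCCCCCNC(=O)[C@H](CO)/N=C/c1ccccc1O`: 19000 nM

Of the two numbers in this assay, compound 2 holds the lower, at 19000 nM. The next compound, compound 3 `CCCCCCCCCCCCCCNC(=O)[C@H](CO)/N=C/c1ccc(Cl)cc1`, is changed on a carbon with a double bond to nitrogen, with 4-chlorophenyl in place of 2-hydroxyphenyl on a carbon with a double bond to nitrogen.

Among the measured compounds shown here, only one measured step bears on this place: a 4.4-fold lower number from compound 1 to compound 2 (0.64 log units; beyond the scatter). There, 2-hydroxyphenyl took the place of 3-methylphenyl, and the step is modest but beyond the scatter. Compound 3 lacks the 2-hydroxyphenyl, as does compound 1 at 82900 nM, so a return toward that higher number is the working expectation. For the measured compounds named here, no measured compound carries 4-chlorophenyl, and one step cannot show how a chlorine-bearing ring compares with a methyl-bearing one, so a full return is not assumed.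

The expected change is a 2.4-fold higher number from compound 2 to compound 3 (0.37 log units; beyond the scatter), a rise somewhat smaller than the measured step. The estimate for compound 3 is 45000 nM, with an expected range of 16000 nM to 120000 nM.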

Compound 3, half-maximal inhibitory concentration: 27500 nM
Estimate against measurement, compound 3: 1.6-fold (0.21 log units) above; the measured number falls inside the stated range.
By their numbers in this assay, from the lowest: compounds 2 and 3 (each within the scatter of the next); then compound 1.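

In this assay, a 2-hydroxyphenyl group on a carbon with a double bond to nitrogen is not required for a number in the range of compound 2: 4-chlorophenyl, which has 0 hydrogen-bond donors and 0 hydrogen-bond acceptors, gives a 1.4-fold higher number from compound 2 to compound 3 (0.16 log units; within the scatter) and so does not separate the two rings. The high number of compound 1 now stands apart from both other compounds, with 4-chlorophenyl in place of 3-methylphenyl giving (a 3.0-fold lower number from compound 1 to compound 3 (0.48 log units; beyond the scatter)), so the first step can no longer be read as a gain specific to 2-hydroxyphenyl. Nothing measured here accounts for two such different rings giving numbers within the scatter of each other.

Among the compounds shown here, with only three rings, each differing in both its substituent and where that substituent sits, the contribution of either cannot be separated from the other. Still open, as far as these compounds go, is how the number would respond to a phenyl ring bearing an amine or a carboxylic acid at this position, or to a longer chain in place of the one in the shared core.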